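The compounds below may be only part of what the source reports. "The series", "measured", "known", "first", "only" and "open" are said of these compounds alone.

Measured so far in a functional assay on the whole organism (strain Swiss albino) with Mus musculus as the target, with a stated time of 4 h; on this read-out lower numbers stand for an effect already at smaller amounts and higher numbers for an effect only at larger amounts of compound:

- compound 1, `C=C(C)[C@@H]1CC=C(C)/C(=N/NC(=O)Nc2nnc(-c3ccc(Cl)cc3)o2)C1`: 300 mg/kg
- compound 2, `CC(C)=CC/C=C(/C)C/C=N/NC(=O)Nc1nnc(-c2ccc(Cl)cc2)o1`: 300 mg/kg

Compound 2 stands level with compound 1 at the digits shown; the two values differ by nothing beyond the scatter, so no order between them is claimed. Among the measured compounds shown here, no step between measured compounds is available, and a single pair at one level gives no sense of how far any change can move the read-out.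

The next compound, compound 3, `CC(C)=CC/C=C(/C)C/C=N/NC(=O)Nc1nnc(-c2ccc(O)cc2)o1`, differs from compound 2 in one place:

hydroxy in place of chloro on an aromatic carbon

The change sits on the aromatic carbon named above, para to a large group. Nothing measured here speaks to this change, so the expected step in this assay is none beyond the scatter: for compound 3 the step of no change at the digits printed from compound 2 to compound 3 (within the scatter) is the estimate. The expected value for compound 3 is 300 mg/kg, with a range from 150 mg/kg to 600 mg/kg.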

Compound 3, minimum effective dose: 300 mg/kg
For compound 3 middle estimate and measured number coincide at the digits printed; the measured number falls inside the stated range.
By their numbers in this assay, from the lowest: compounds 1, 2 and 3 (each within the scatter of the next).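

In this assay, among the compounds shown here, the first step that can be read is no change at the digits printed from compound 2 to compound 3 (within the scatter) for hydroxy in place of chloro on an aromatic carbon, para to a large group. The change from 4-chlorophenyl to 4-hydroxyphenyl, with a hydrogen-bond donor and acceptor entering, therefore leaves the read-out unmoved, so this position accepts this one exchange with no visible effect on the minimum effective dose. Nothing at hand accounts for this outcome.

On these data alone, whether an amine, a carboxylic acid or a methoxy group on the same carbon would shift the read-out remains open. With every compound shown at one level, it also remains open how far any change at this position can move the read-out, and whether the same exchange would behave alike on the core of compound 1.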